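Chain extension on the N-methyl naphthonitrile uricosuric series

This account rests on a few compounds, and the source may have more. Where it says the series, first, only, none or still open, it means among the compounds named here.

Compound 1: `N#Cc1ccc(Nc2cnccc2SCCCCCCC(=O)O)c2ccccc12` — 5750 nM
Compound 2: `CN(c1cnccc1SCCCC(=O)O)c1ccc(C#N)c2ccccc12` — 2580 nM

Of the compounds shown here, two have been measured in an assay on HEK293 cells for inhibition of solute carrier family 22 member 12 (Homo sapiens), read by scintillation counting, with stated times of 30 min and 15 min; on this read-out lower numbers stand for stronger inhibition and higher numbers for weaker inhibition. Compound 1 gives 5750 nM. Compound 2 gives 2580 nM, the lower of the two numbers, and the gap up to compound 1 lies beyond the usual scatter. For the measured compounds named here, no two measured compounds differ in one place only, so neither the methyl on the nitrogen nor the chain length can be read out on its own.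

Compound 3 is `CN(c1cnccc1SCCCCCCC(=O)O)c1ccc(C#N)c2ccccc12`. It differs from compound 2 by 3-carboxypropyl in place of carboxy on a saturated chain carbon, three bonds along the chain from a sulfur, and it carries the same chain as compound 1 together with the methylated nitrogen of compound 2. Going by the values given here, with no single-change step available, the expectation rests only on the values of compound 1 and compound 2: a step in this assay of modest size, in either direction, or none beyond the scatter. The number expected for compound 3 is 3500 nM, in the range 1200 nM to 10000 nM, a step of a 1.4-fold higher number from compound 2 to compound 3 (0.13 log units; within the scatter) that is estimated, not measured.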

Compound 3, half-maximal inhibitory concentration: 4640 nM
The estimate for compound 3 lay 1.3-fold (0.12 log units) below the measured number, within the range that was stated.
By their numbers in this assay, from the lowest: compounds 2, 3 and 1 (each within the scatter of the next, the first and the last beyond it).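

In this assay, the two new steps allow each change to be read on its own: 3-carboxypropyl in place of carboxy on a saturated chain carbon, three bonds along the chain from a sulfur, gives a 1.8-fold higher number from compound 2 to compound 3 (0.25 log units; within the scatter), and methyl in place of hydrogen on a nitrogen on an aromatic ring gives a 1.2-fold lower number from compound 1 to compound 3 (0.09 log units; within the scatter). Taken singly, neither the added chain length nor the methyl on the nitrogen separates from the usual scatter of this measurement. No measurement shown bears on why these steps have the size they do.

The compounds shown leave open how a longer chain, or one of intermediate length, would read at this position. They also leave open what an ethyl on the nitrogen, or a tetrazole in place of the carboxylic acid, would do.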